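Removing one fluorine from the tetrafluorophenyl tail

A few compounds are considered here, and "the series" means these few. Any claim that something is new, unique, unknown or untested is made for them only; others in the source may bear on it.

Notes on two antagonists measured in a functional assay on CHO-K1 cells for antagonist activity at cysteinyl leukotriene receptor 1 (Homo sapiens), read by fluorescence and calcium flux, with stated times of 30 min and 1 h; a lower number here means a stronger inhibitor, a higher number a weaker inhibitor. Compound 1 `O=C(O)CCCc1cn(CC(=O)O)c2c(/C=C/c3ccc(OCCCCc4c(F)ccc(F)c4F)cc3)cccc12` gives 1 nM in this assay. Compound 2 `Cc1c(CCCC(=O)O)c2cccc(/C=C/c3ccc(OCCCCc4c(F)cc(F)c(F)c4F)cc3)c2n1CC(=O)O` gives 1.6 nM in this assay; it holds the higher of the two numbers, yet its gap to compound 1 lies within the scatter, so the two cannot be told apart. Compound 3 `Cc1c(CCCC(=O)O)c2cccc(/C=C/c3ccc(OCCCCc4c(F)ccc(F)c4F)cc3)c2n1CC(=O)O` is not yet measured and differs from compound 2 in one place: hydrogen in place of fluoro on an aromatic carbon. Compound 1, at 1 nM, carries the same 2,3,6-trifluorophenyl group on a different core and sits within the scatter of compound 2, which gives no sign that this end of the molecule moves the number much. The step from compound 2 to compound 3 is therefore expected to stay within the scatter, a 1.1-fold lower number from compound 2 to compound 3 (0.06 log units; within the scatter), with no direction claimed. Compound 3 is estimated at 1.4 nM, with a range from 0.6 nM to 3.5 nM.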

Compound 3, half-maximal inhibitory concentration: 2.4 nM
For compound 3 the middle estimate is 1.7-fold (0.23 log units) below the measured one; the range from low to high includes it.
By their numbers in this assay, from the lowest: compounds 1, 2 and 3 (each within the scatter of the next, the first and the last beyond it).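

In this assay, hydrogen in place of fluoro on the carbon para to a large group gives a 1.5-fold higher number from compound 2 to compound 3 (0.18 log units; within the scatter), so the 2,3,4,6-tetrafluorophenyl and 2,3,6-trifluorophenyl tails cannot be told apart on this core. With the 2,3,6-trifluorophenyl tail held constant, methyl in place of hydrogen on an aromatic carbon gives a 2.4-fold higher number from compound 1 to compound 3 (0.38 log units; beyond the scatter), a modest step and the only one here beyond the scatter. Nothing shown explains the size of either step.

Open, from the compounds shown here alone, is whether chloro, methoxy or trifluoromethyl on the same aromatic carbon of the tail would also stay within the scatter of fluoro and hydrogen. Also open, going by these compounds, is whether ethyl in place of the methyl would extend the modest step or leave the number within the scatter of compound 3.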